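Exchanging a Furan for a Pyridine on the Side Chain

A few compounds are considered here, and "the series" means these few. Any claim that something is new, unique, unknown or untested is made for them only; others in the source may bear on it.

Of the compounds shown here, three with a shared core have been measured. Compound 1 `Nc1nc(NCc2cccs2)nc2sc(-c3ccco3)nc12` in a functional assay on CHO cells for agonist activity at adenosine receptor A2b (Homo sapiens), read by scintillation counting and cAMP accumulation, with a stated time of 150 min, in the presence of a further agent that is not named here (on this read-out higher numbers stand for weaker inhibition and lower numbers for stronger inhibition), gives 75 nM. Compound 2 `Cc1ccc(-c2nc3c(N)nc(NCc4cccs4)nc3s2)o1` carries a methyl in place of hydrogen on an aromatic carbon, and in this assay compound 2 gives 91 nM, a step of a 1.2-fold higher number from compound 1 to compound 2 (0.08 log units; within the scatter). Compound 3 `Nc1nc(NCc2ccco2)nc2sc(-c3ccco3)nc12` carries furan-2-yl in place of thiophen-2-yl on a saturated chain carbon bound to a nitrogen on an aromatic ring, and in this assay compound 3 gives 82 nM, a step of a 1.1-fold higher number from compound 1 to compound 3 (0.04 log units; within the scatter). Compound 3 thus has the second highest of the three numbers, yet all three lie within the usual scatter of one another, so no ordering among them can be claimed.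

Compound 4 `Nc1nc(NCc2cccnc2)nc2sc(-c3ccco3)nc12` differs from compound 3 by pyridin-3-yl in place of furan-2-yl on a saturated chain carbon bound to a nitrogen on an aromatic ring. Within the data shown here, only one measured step touches the same place, the exchange from compound 1 to compound 3 of a 1.1-fold higher number from compound 1 to compound 3 (0.04 log units; within the scatter), and it stayed within the scatter. Among the measured compounds shown here, no measured step exchanges a ring of this kind for a ring of the other kind, so the guidance is indirect. On this basis the expected step is a 1.5-fold higher number from compound 3 to compound 4 (0.17 log units; within the scatter), roughly no change beyond the scatter, with a slight lean toward a higher number. Compound 4 is therefore estimated at 120 nM, with a range from 50 nM to 400 nM.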

Compound 4, half-maximal inhibitory concentration: 109 nM
Beside the measured number, compound 4's estimate is 1.1-fold (0.04 log units) above it, within the range that was stated.
By their numbers in this assay, from the lowest: compounds 1, 3, 2 and 4 (each within the scatter of the next).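

The earlier compounds shown here only swapped one five-membered aromatic ring for another on this side chain, whereas compound 4 puts a six-membered aromatic ring, pyridin-3-yl, on the saturated chain carbon bound to a nitrogen on an aromatic ring. The result is a step of a 1.3-fold higher number from compound 3 to compound 4 (0.12 log units; within the scatter) and, against the thiophen-2-yl of compound 1, a step of a 1.5-fold higher number from compound 1 to compound 4 (0.16 log units; within the scatter) as well. Both steps stay within the scatter, so across these three compounds, changing ring size from 5 to 6 heavy atoms and replacing a ring oxygen or sulfur with a ring nitrogen gives no change that can be claimed, and nothing available explains this flat result.

The compounds shown cover only one pyridine, so it remains open whether moving the ring nitrogen, as in pyridin-2-yl or pyridin-4-yl, would change the number. From the compounds shown here alone, it is also open whether a step beyond the scatter would come from a group of a different kind at this place, such as a saturated piperidine ring, a plain phenyl ring, or a longer chain carrying the same ring.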